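The compounds below may be only part of what the source reports. "The series", "measured", "known", "first", "only" and "open" are said of these compounds alone.

Compound 1 `CC(C)(C)OC(=O)N1CCN(C(=S)SCc2cn(-c3ccccc3F)nn2)CC1` — > 128000 nM
Compound 2 `CC(C)(C)OC(=O)N1CCN(C(=S)SCc2cn(Cc3cc(=O)oc4cc(O)ccc34)nn2)CC1` — > 128000 nM
Compound 3 `COc1cc(Cn2cc(CSC(=S)N3CCN(C(=O)OCc4ccccc4)CC3)nn2)cc(OC)c1OC` — > 128000 nM

Of the compounds shown here, three have been measured in a functional assay on ECa-109 cells (Homo sapiens) for inhibition, read by MTT assay, with a stated time of 72 h; a higher number here means a weaker inhibitor, a lower number a stronger inhibitor. Compound 1 returns only a limit in this assay, > 128000 nM, and no number. Compound 2 likewise returns only a limit, > 128000 nM. Compound 3 also gives a limit, > 128000 nM. Compound 1 therefore stands where every measured value stands, at the limit of > 128000 nM in this assay, at which 3 of the 3 values shown sit. No two of these compounds differ in a single place, so no measured step is available to guide expectations.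

Compound 4 `COc1ccc(-n2cc(CSC(=S)N3CCN(C(=O)OC(C)(C)C)CC3)nn2)cc1` differs from compound 1 as follows: 4-methoxyphenyl in place of 2-fluorophenyl on an aromatic nitrogen. Among the measured compounds shown here, compound 1 sits at the limit > 128000 nM, and the other measured compounds offer no step to weigh against this change. The expected step in this assay is accordingly none beyond the usual scatter, a number no higher from compound 1 to compound 4 (the limit leaves the size open). Compound 4 is estimated at 128000 nM in this assay, with a range from 40000 nM to 400000 nM, and the assay is expected to report only a limit again.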

Compound 4, half-maximal inhibitory concentration: > 128000 nM
Compound 4 gave a limit, no number (the forecaster's own chance of this, stated with the estimate: 85%); the middle value lies on the limit itself.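

No step can be read from compound 1 to compound 4 in this assay, since each returns only a limit and no number: the limit of > 128000 nM in this assay, at which 4 of the 4 values shown sit.

The compounds shown leave open how 4-methoxyphenyl and 2-fluorophenyl compare, and which change, if any, would yield a readable number in this assay.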